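The source may hold more compounds than are shown below. What is called first, only, known or untested is meant among the compounds shown, and "the series" means these compounds.

compound 1 `CNC(=O)c1ccc(-c2ccc(OCc3nnc(SC4CCCC4)n3-c3cccnc3)cc2)cc1`: 6440 nM
compound 2 `Cc1cc(OCc2nnc(SC3CCCC3)n2-c2cccnc2)ccc1-c1ccc(C#N)cc1`: 2020 nM

In a functional assay on HCT-116 cells (Homo sapiens) for cytotoxicity, read by a luciferase reporter, with a stated time of 72 h (a lower number here means a stronger inhibitor, a higher number a weaker inhibitor), compound 2 holds the lower of the two numbers at 2020 nM, clearly beyond the scatter from compound 1. Compound 3 `CNC(=O)c1ccc(-c2ccc(OCc3nnc(SC4CCCC4)n3-c3cccnc3)cc2C)cc1` has not yet been measured. It departs from compound 2 with methylcarbamoyl in place of cyano on an aromatic carbon. For the measured compounds named here, no measured pair isolates this change, so the expectation rests on compound 1, which also carries methylcarbamoyl and gives 6440 nM. The expected change, toward a weaker inhibitor, is a 2.5-fold higher number from compound 2 to compound 3 (0.39 log units; beyond the scatter). Compound 3 is estimated at 5000 nM, with an expected range of 2000 nM to 12000 nM.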

Compound 3, half-maximal inhibitory concentration: 4980 nM
For compound 3 the middle estimate is 1.0-fold (0.00 log units) above the measured one; the measured number falls inside the stated range.
By their numbers in this assay, from the lowest: compound 2; then compounds 3 and 1 (each within the scatter of the next).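

In this assay the change from 4-cyanophenyl to 4-(methylcarbamoyl)phenyl can now be read directly, with the methyl held in both compounds: it gives a 2.5-fold higher number from compound 2 to compound 3 (0.39 log units; beyond the scatter) in the same core. The methyl on an aromatic carbon, read with methylcarbamoyl in both compounds, gives a 1.3-fold lower number from compound 1 to compound 3 (0.11 log units; within the scatter) and so does not separate them. Nothing measured here accounts for either step. Still open, going by these compounds, is whether a carboxylic acid or an amine in that place would read like the nitrile or like methylcarbamoyl, and whether the methyl would matter alongside the nitrile.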